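Series notes: aryl swap at the exocyclic double bond

The source may report more compounds than this note shows. Statements on the series, on what has been measured and on what is new or still open speak of the compounds shown alone.

Compound 3 `COc1ccccc1/C=C1\CN(CC(=O)O)c2c(C)cccc2C1=O` carries a 2-methoxyphenyl on the double-bonded chain carbon bound to a double-bonded ring carbon. In an assay on HL-60 cells for inhibition of glutathione S-transferase P (Homo sapiens), read by spectrophotometry, tested at 20 uM (a lower number here means less inhibition, a higher number more inhibition at the concentration tested (going by the name of the read-out)), compound 3 gives 4.72%, the lowest of the three numbers; compound 1 `Cc1cccc2c1N(CC(=O)O)C/C(=C\c1ccccc1)C2=O` gives 27.9% and compound 2 `Cc1cccc(/C=C2\CN(CC(=O)O)c3c(C)cccc3C2=O)c1` gives 39.1%, both beyond the scatter above it. Compound 4 `Cc1cc(C)cc(/C=C2\CN(CC(=O)O)c3c(C)cccc3C2=O)c1` is not yet measured; it differs from compound 3 as follows: 3,5-dimethylphenyl in place of 2-methoxyphenyl on a double-bonded chain carbon bound to a double-bonded ring carbon.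

Within the data shown here, three measured steps bear on this. Among the measured compounds shown here, the step of a number 34.4 percentage points lower from compound 2 to compound 3 (beyond the scatter) is the closest precedent, as it is the reverse of the aryl swap now made, apart from the second methyl. The step of a number 23.2 percentage points lower from compound 1 to compound 3 (beyond the scatter) shows the methoxy alone costing inhibition, and the step of a number 11.2 percentage points higher from compound 1 to compound 2 (beyond the scatter) shows an added methyl gaining it. Taken together, a large upward step a number 41.3 percentage points higher from compound 3 to compound 4 (beyond the scatter) is expected, placing compound 4 near compound 2 or somewhat higher. For compound 4 the estimate is 46%, with a range from 26% to 66%.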

Compound 4, a percentage reported as inhibition, at one concentration (the size of the read-out at that concentration, not a potency): 17.5%
Compound 4: middle estimate off by 28.5 percentage points, on the high side, outside the stated range (below it).
By their numbers in this assay, from the lowest: compound 3; then compound 4; then compound 1; then compound 2.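

In this assay, methyl groups on the aryl ring do not add up: the second methyl gives a number 21.6 percentage points lower from compound 2 to compound 4 (beyond the scatter), which reverses the gain seen with the first. The 3,5-dimethylphenyl group also falls short of plain phenyl, with a number 10.4 percentage points lower from compound 1 to compound 4 (beyond the scatter), so across compound 1, compound 2 and compound 4 the number rises and then falls as methyls are added. Replacing 2-methoxyphenyl with 3,5-dimethylphenyl still gives a number 12.8 percentage points higher from compound 3 to compound 4 (beyond the scatter), so compound 3 remains the lowest of the four, but this swap does not bring the number back to the level of compound 1.

Nothing available explains the drop that comes with the second methyl. On these data alone, it remains open how this position responds to an aryl ring carrying an amine or a nitrile.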